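Methylating a Hydroxy Group on Compound 1

This account rests on a few compounds, and the source may have more. Where it says the series, first, only, none or still open, it means among the compounds named here.

Compound 1 `Cc1cc(/C=C/c2ccc(O)c(O)c2)on1`: 3300 nM
Compound 2 `Cc1cc(/C=C/c2ccc(O)c(O)c2)[nH]n1`: 23200 nM

In a functional assay on PC-3 cells (Homo sapiens) for cytotoxicity, read by MTT assay, with a stated time of 72 h (a higher number here means a weaker inhibitor, a lower number a stronger inhibitor), compound 1 holds the lower of the two numbers, and the gap up to compound 2 lies beyond the usual scatter. Compound 1 is therefore the stronger inhibitor of this pair.

Compound 3 `COc1cc(/C=C/c2cc(C)no2)ccc1O` departs from compound 1 at a single place: methyl in place of hydrogen on an oxygen on an aromatic ring. This puts methyl in place of hydrogen on an oxygen on an aromatic ring, turning hydroxy to methoxy. Among the compounds with values here, no measured pair shows this change, so the expectation is a judgement rather than a reading from the data. A move toward a higher number in this assay seems more likely than no change, and it probably lies modestly beyond the scatter. The estimated step is a 3.3-fold higher number from compound 1 to compound 3 (0.52 log units; beyond the scatter). For compound 3 the expected value is 11000 nM, with an estimated range from 3500 nM to 35000 nM.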

Compound 3, half-maximal inhibitory concentration: 20900 nM
Compound 3: the middle estimate sits 1.9-fold (0.28 log units) below what was measured; the range from low to high includes it.
By their numbers in this assay, from the lowest: compound 1; then compounds 3 and 2 (each within the scatter of the next).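

Turning hydroxy to methoxy is the first change in this set that can be read as a single step, and in this assay it gives a 6.3-fold higher number from compound 1 to compound 3 (0.80 log units; beyond the scatter), a move beyond the scatter. The hydrogen on this oxygen therefore matters to the reading, since methyl in its place costs compound 3 a clear part of the inhibition that compound 1 shows, although this rests on one pair alone. Nothing measured here accounts for the step.

The compounds shown leave open whether the remaining hydroxy on the ring of compound 3 would respond in the same way to methyl, and whether the same change would give a similar step on the core of compound 2. They also leave open how an ethoxy group or an amine would read in place of this hydroxy.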